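The source may hold more compounds than are shown below. What is called first, only, known or untested is meant among the compounds shown, and "the series" means these compounds.

In an ADME assay on MCF7 cells (Homo sapiens) for cytotoxicity, read by sulforhodamine B assay, with a stated time of 48 h (a lower number here means that less compound is tolerated, a higher number that more compound is tolerated), three compounds sharing one core have been measured. Compound 1 `O=C1/C(=C/c2ccc3ccccc3c2)CNC/C1=C\c1ccc2ccccc2c1` gives 97500 nM, the higher of the two true numbers. Compound 2 `O=C1/C(=C/c2cccs2)CNC/C1=C\c1cccs1` gives > 100000 nM, which is a limit of the assay and not a number. Compound 3 `O=C1/C(=C/c2c[nH]c3ccccc23)CNC/C1=C\c1c[nH]c2ccccc12` gives 8200 nM, lower than compound 1 by more than the scatter.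

Compound 4 `C=CC(=O)N1C/C(=C\c2ccc3ccccc3c2)C(=O)/C(=C/c2ccc3ccccc3c2)C1` keeps the core of compound 1 and carries one change: vinylcarbonyl in place of hydrogen on an amine nitrogen in a ring. Among the compounds with values here, no measured pair shows this change, so any forecast is a judgement. A drop beyond the scatter is expected in this assay, since compound 3 at 8200 nM shows that this core can reach much lower numbers. The estimated step is a 9.8-fold lower number from compound 1 to compound 4 (0.99 log units; beyond the scatter). For compound 4 the expected value is 10000 nM, within an estimated range of 1500 nM to 60000 nM.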

Compound 4, concentration lethal to 50% of the cells: 9200 nM
Compound 4: middle estimate off by 1.1-fold (0.04 log units), on the high side; the measured number falls inside the stated range.
By their numbers in this assay, from the lowest: compounds 3 and 4 (each within the scatter of the next); then compound 1. At a limit, above all of these: compound 2.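

In this assay, the amine nitrogen in the ring proves to be a place where one change matters: vinylcarbonyl in place of hydrogen gives an 11-fold lower number from compound 1 to compound 4 (1.03 log units; beyond the scatter). Within the data shown here, this is the first step here that can be read as a single change on the shared core, and it means that less compound is tolerated. Nothing measured here explains the step. The compounds shown leave open whether the vinyl part of the group is needed, which an acetyl group on the same nitrogen could test.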